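The source may hold more compounds than are shown below. What is called first, only, known or untested is meant among the compounds shown, and "the series" means these compounds.

For the measured compounds named here, compound 2 `CCCn1c(-c2ccco2)nc2c(NCc3ccccc3)ncnc21` carries the lower of the two numbers measured so far. In an assay on CHO cells for displacement of a labelled ligand from adenosine receptor A1 (Homo sapiens) (on this read-out higher numbers stand for weaker inhibition and lower numbers for stronger inhibition), compound 2 gives 546 nM. Going by the values given here, the only other measured compound is compound 1 `CCCn1cnc2c(NCCCc3ccccc3)ncnc21`, which differs from compound 2 in two places at once, so no single change can be read from the pair; in this assay compound 1 gives 18600 nM, a far weaker result that lies well beyond the scatter. Compound 3 `CCCn1c(-c2ccco2)nc2c(NCCCc3ccccc3)ncnc21` has not yet been measured. It differs from compound 2 in one place only: phenethyl in place of phenyl on a saturated chain carbon bound to a nitrogen on an aromatic ring. Some loss of potency is expected for compound 3 because compound 1 with the same longer chain gives 18600 nM, although compound 1 also differs elsewhere, so the size is uncertain. The expected step is a weakening of a 3.7-fold higher number from compound 2 to compound 3 (0.56 log units; beyond the scatter). Compound 3 is estimated at about 2000 nM, with a range from 500 nM to 8000 nM.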

Compound 3, inhibition constant: 378 nM
The estimate for compound 3 lay 5.3-fold (0.72 log units) above the measured number; the measured number lies below the stated range.
By their numbers in this assay, from the lowest: compounds 3 and 2 (each within the scatter of the next); then compound 1.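

With furan-2-yl on the core, exchanging benzyl for 3-phenylpropyl gives a 1.4-fold lower number from compound 2 to compound 3 (0.16 log units; within the scatter) in this assay and so leaves the number effectively unchanged. For the compounds shown here, this is the first direct reading of this chain, and within these two compounds the added length shows no measurable cost. Compounds 1 and 3 now also form a clean pair: furan-2-yl in place of hydrogen on an aromatic carbon gives a 49-fold lower number from compound 1 to compound 3 (1.69 log units; beyond the scatter) and is the large change in this set, so the weak number of compound 1 goes with the missing furan-2-yl and not with its 3-phenylpropyl chain.

Still open, as far as these compounds go, is whether a longer chain than 3-phenylpropyl would be tolerated equally, and whether a thiophene could replace furan-2-yl with a similar gain. No measurement shown gives a reason for either step.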